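A few compounds are considered here, and "the series" means these few. Any claim that something is new, unique, unknown or untested is made for them only; others in the source may bear on it.

Measured compounds in a functional assay on MDA-MB-231 cells (Homo sapiens) for antiproliferative activity, read by sulforhodamine B assay; a lower number here means a stronger inhibitor of growth, a higher number a weaker inhibitor of growth:
compound 1 `Cc1ccc(C(=O)Nc2nc3cc(C)cc(C)c3s2)cc1` gives 0.44 ug/mL;
compound 2 `COc1ccc2sc(NC(=O)c3ccc(C(F)(F)F)cc3)nc2c1` gives > 10 ug/mL;
compound 3 `Cc1cc2nc(NC(=O)Nc3ccccc3C)sc2cc1C` gives 0.1 ug/mL.

Compound 2 stands at the edge of this assay: its value of > 10 ug/mL is a limit, not a number, and the limit of > 10 ug/mL in this assay, at which 1 of the 3 values shown sits, marks where it sits. Compound 4 `COc1ccc2sc(NC(=O)c3ccc(C#N)cc3)nc2c1` differs from compound 2 in one place: cyano in place of trifluoromethyl on an aromatic carbon. Among the compounds with values here, no step between two measured compounds is available in this set, so the size of the change from compound 2 to compound 4 rests on expectation alone. Cyano in place of trifluoromethyl on an aromatic carbon is expected to keep the result close to the limit, with perhaps a modest gain; the step from compound 2 to compound 4 is estimated as an at least 1.2-fold lower number from compound 2 to compound 4 (0.09 log units; that floor lies within the scatter). Compound 4 is estimated at 8 ug/mL, within 2 ug/mL to 30 ug/mL.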

Compound 4, concentration for 50% growth inhibition: > 10 ug/mL
Compound 4: no number, only a limit; the forecaster's own chance of this, stated with the estimate: 45%; middle value at least 1.2-fold (0.09 log units) from the limit.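

Compound 2 and compound 4 each give only a limit, not a number, in this assay, so no step between them can be read: the limit of > 10 ug/mL in this assay, at which 2 of the 4 values shown sit.

From the compounds shown here alone, whether cyano in place of trifluoromethyl on an aromatic carbon changes growth inhibition at all remains open.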